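The source may report more compounds than this note shows. Statements on the series, on what has been measured and on what is new or still open speak of the compounds shown alone.

The measured compounds and their values in a functional assay on aorta (Rattus norvegicus) for inhibition; on this read-out lower numbers stand for stronger inhibition and higher numbers for weaker inhibition:

Compound 1, `O=C(Nc1cc2cc[nH]c(=O)c2cc1Cl)C1CNCC1c1ccc(F)cc1`, gives 160 nM.
Compound 2, `O=C(Nc1cc2cc[nH]c(=O)c2cc1Cl)C1CNCC1c1ccccn1`, gives 210 nM.
Compound 3, `CC(C)(C)c1cccc(C2CNCC2C(=O)Nc2cc3cc[nH]c(=O)c3cc2Cl)c1`, gives "not determined" (no result reported).

Compound 3 therefore stands nowhere on the numbers shown; it shares the core of compound 1 and compound 2 but carries a different aromatic group. Compound 4, `O=C(Nc1cc2cc[nH]c(=O)c2cc1Cl)C1CNCC1c1cccc(Br)c1`, differs from it by bromo in place of tert-butyl on an aromatic carbon. The one measured step, a 1.3-fold higher number from compound 1 to compound 2 (0.12 log units; within the scatter), exchanges the whole aromatic group and stays within the scatter, so the aromatic group appears to tolerate variation among these compounds. Nothing measured bears directly on the change from tert-butyl to bromo, so no step beyond the scatter is expected. Compound 4 is estimated to give 250 nM in this assay, within 80 nM to 800 nM.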

Compound 4, half-maximal inhibitory concentration: 63 nM
Estimate against measurement, compound 4: 4.0-fold (0.60 log units) above, outside the stated range (below it).
By their numbers in this assay, from the lowest: compound 4; then compounds 1 and 2 (each within the scatter of the next).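

In this assay the aromatic group on the saturated ring carbon is not as freely exchangeable as the first two compounds suggested. Replacing pyridin-2-yl with 3-bromophenyl gives a 3.3-fold lower number from compound 2 to compound 4 (0.52 log units; beyond the scatter) and replacing 4-fluorophenyl with it gives a 2.5-fold lower number from compound 1 to compound 4 (0.40 log units; beyond the scatter) and both steps lie beyond the scatter. Nothing shown accounts for this difference. With no number for compound 3, the change from tert-butyl to bromo cannot be read. From the compounds shown here alone, whether a plain phenyl, or an amine or carboxylic acid in place of bromo, would keep this level remains open.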